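Phenyl to 4-chlorophenyl: working notes on the series

The compounds below may be only part of what the source reports. "The series", "measured", "known", "first", "only" and "open" are said of these compounds alone.

In a functional assay on HeLa cells (Homo sapiens) for cytotoxicity, read by MTT assay, with a stated time of 72 h (a lower number here means a stronger inhibitor, a higher number a weaker inhibitor), compound 2 `O=C(Nc1ccc(Oc2ncnc3[nH]ccc23)c(F)c1)c1cc2cccnc2n(-c2ccccc2)c1=O` gives 36900 nM and compound 1 `Cn1ccc2c(Oc3ccc(NC(=O)c4cc5cccnc5n(-c5ccccc5)c4=O)cc3F)ncnc21` gives 51800 nM so the two sit within the scatter of each other. Compound 3 `O=C(Nc1ccc(Oc2ncnc3[nH]ccc23)c(F)c1)c1cc2cccnc2n(-c2ccc(Cl)cc2)c1=O` changes phenyl to 4-chlorophenyl, with chloro in place of hydrogen on an aromatic carbon. Among the measured compounds shown here, the only measured step (a 1.4-fold lower number from compound 1 to compound 2 (0.15 log units; within the scatter)) is hydrogen in place of methyl on an aromatic nitrogen, a different part of the structure, so it offers only weak guidance. No step beyond the scatter is therefore expected in this assay and the expected step is small (a 1.2-fold lower number from compound 2 to compound 3 (0.09 log units; within the scatter)). For compound 3 the estimated value is 30000 nM (expected range 12000 nM to 70000 nM).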

Compound 3, half-maximal inhibitory concentration: 23900 nM
Beside the measured number, compound 3's estimate is 1.3-fold (0.10 log units) above it; low and high end bracket the measured number.
By their numbers in this assay, from the lowest: compounds 3, 2 and 1 (each within the scatter of the next, the first and the last beyond it).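

In this assay, chloro on an aromatic carbon of the six-membered carbon ring, para to a large group, gives a 1.5-fold lower number from compound 2 to compound 3 (0.19 log units; within the scatter). Among the compounds shown here, the earlier pair spoke only to the aromatic nitrogen; this step is the first reading at the phenyl, and there a single chlorine leaves compound 3 within the scatter of compound 2. Nothing measured explains the size of this step.

As far as these compounds go, whether an amine, a carboxylic acid or a methoxy group at this place would also stay within the scatter remains open. So does whether 4-chlorophenyl behaves the same way with the methyl of compound 1 on the aromatic nitrogen.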